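The compounds below may be only part of what the source reports. "The series", "measured", "known", "first", "only" and "open" are said of these compounds alone.

Compound 2 `COc1ccc(/C=C2\CCC/C(=C\c3ccc(OC)c(OC)c3)C2=O)cc1` gives 6600 nM in a functional assay on SW-620 cells (Homo sapiens) for cytotoxicity, read by MTT assay, with a stated time of 72 h; on this read-out higher numbers stand for weaker inhibition and lower numbers for stronger inhibition. That is the only plain number shown; the other two values sit at the limit of > 20000 nM in this assay, at which 2 of the 3 values shown sit. Compound 1 `COc1ccc(/C=C2\CCC/C(=C\c3cccc(OC)c3OC)C2=O)c(OC)c1` reaches only the limit > 20000 nM. Compound 3 `COc1ccc(/C=C2\CCC/C(=C\c3ccc(OC)c(OC)c3)C2=O)c(OC)c1` likewise stops at the limit > 20000 nM. Within the data shown here, the one measured step, an at least 3.0-fold higher number from compound 2 to compound 3 (0.48 log units; beyond the scatter), shows that methoxy in place of hydrogen on an aromatic carbon weakened inhibition. Compound 4 `COc1cc(/C=C2\CCC/C(=C\c3ccc(OC)c(OC)c3)C2=O)ccc1O` differs from compound 2 by 4-hydroxy-3-methoxyphenyl in place of 4-methoxyphenyl on a double-bonded chain carbon bound to a double-bonded ring carbon. The step from compound 2 to compound 3 adds a group to a different ring and is only a loose guide, yet it is the sole one, so a modest rise in the number, or none beyond the scatter, is expected. Compound 4 is therefore estimated at 9000 nM, between 3000 nM and 20000 nM, meaning a 1.4-fold higher number from compound 2 to compound 4 (0.13 log units; within the scatter).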

Compound 4, half-maximal inhibitory concentration: 4500 nM
Compound 4: the middle estimate sits 2.0-fold (0.30 log units) above what was measured, within the range that was stated.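

The step gives a 1.5-fold lower number from compound 2 to compound 4 (0.17 log units; within the scatter), so in this assay this replacement keeps compound 4 a plain number, with no change beyond the scatter. The earlier step, an at least 3.0-fold higher number from compound 2 to compound 3 (0.48 log units; beyond the scatter), showed only that one added methoxy can push the number to a limit; here a hydroxy together with a second methoxy on the same ring does not.

The compounds shown do not separate the hydroxy from the added methoxy, and they leave open how an amine or a carboxylic acid would read on this ring. Other comparisons stop at a limit: the limit of > 20000 nM in this assay, at which 2 of the 4 values shown sit.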